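A few compounds are considered here, and "the series" means these few. Any claim that something is new, unique, unknown or untested is made for them only; others in the source may bear on it.

Measured compounds:

Compound 1, `CC(C)CN(NC(=O)OCc1ccccc1)C(=O)CN(Cc1ccccc1)NC(=O)Cc1cccc(Br)c1`, gives 15800 nM in a functional assay on B16 cells (Mus musculus) for inhibition; on this read-out lower numbers stand for stronger inhibition and higher numbers for weaker inhibition.
Compound 2, `CC(C)CN(CC(=O)NN(Cc1ccccc1)c1cnccn1)NC(=O)Cc1cccc(Br)c1`, gives 33300 nM in this assay.
Compound 3, `CC(C)CN(NC(=O)OCc1ccccc1)C(=O)CN(Cc1ccccc1)/N=C/c1cccc(B(O)O)c1`, gives 18400 nM in this assay.

Compound 1 and compound 3 share a core and differ in one place: a group of 11 heavy atoms (7 carbon, 1 boron, 1 nitrogen, 2 oxygen; one six-membered aromatic ring of carbon only) in place of a group of 11 heavy atoms (8 carbon, 1 nitrogen, 1 oxygen, 1 bromine; one six-membered aromatic ring of carbon only), on an amine nitrogen. This change gave a 1.2-fold higher number from compound 1 to compound 3 (0.07 log units; within the scatter), so the exchange of the bromine-bearing group for the boron-bearing group left the read-out essentially where it was.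

Compound 2 is built on a different core, and the difference between the two cores is not broken down here. Its number is higher than that of compound 1, while its number and that of compound 3 lie close enough to each other that no order can be read from them.

Compound 4, `CC(C)CN(CC(=O)NN(Cc1ccccc1)c1cnccn1)/N=C/c1cccc(B(O)O)c1`, is not yet measured. It stands to compound 2 as compound 3 stands to compound 1: the same change, (a group of 11 heavy atoms (7 carbon, 1 boron, 1 nitrogen, 2 oxygen; one six-membered aromatic ring of carbon only) in place of a group of 11 heavy atoms (8 carbon, 1 nitrogen, 1 oxygen, 1 bromine; one six-membered aromatic ring of carbon only), on an amine nitrogen), made at a place described in the same words. Among the compounds with values here, since this change gave a 1.2-fold higher number from compound 1 to compound 3 (0.07 log units; within the scatter) on the other core, a step of similar size is expected here, with the caveat that the pair compound 1 and compound 3 is the only example of it among the measured compounds. The expected step is a 1.1-fold higher number from compound 2 to compound 4 (0.06 log units; within the scatter), resting on that single precedent and on compound 2 giving 33300 nM. Compound 4 is therefore estimated at 38000 nM, with a likely range from 17000 nM to 85000 nM.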

Compound 4, half-maximal inhibitory concentration: 33700 nM
Compound 4: middle estimate off by 1.1-fold (0.05 log units), on the high side; low and high end bracket the measured number.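

In this assay the new step is a 1.0-fold higher number from compound 2 to compound 4 (0.01 log units; within the scatter) and so, on the core of compound 2 as well, putting the boron-bearing group in place of the bromine-bearing group on the amine nitrogen leaves the read-out essentially where it was. Set side by side, the two steps do not differ, so in this series the change carried over from one core to the other with the same result, a step too small to read: the same change on two cores in this assay, a 1.2-fold higher number (0.07 log units; within the scatter) from compound 1 to compound 3 and a 1.0-fold higher number (0.01 log units; within the scatter) from compound 2 to compound 4, 1.2-fold (0.06 log units) apart, within the scatter of two such steps. Within the data shown here, this rests on only two pairs, and it shows neither that the change would stay this small on a third core nor why neither core responds to it, since two steps that both stay within the scatter say only that no effect could be detected here.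

The compounds shown leave open whether a different group on the same amine nitrogen, such as one carrying a carboxylic acid or an amine on its aromatic ring, would move the number at all. They also leave open what part of the boron-bearing group matters, if any does, and whether the same exchange would behave alike on a core with a longer chain in place of the shared benzyl group.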